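Replacing a Nitro Group with Fluorine on the Benzyl Arm

A few compounds are considered here, and "the series" means these few. Any claim that something is new, unique, unknown or untested is made for them only; others in the source may bear on it.

Of the compounds shown here, three built on one shared core have so far been tested in a functional assay on HepG2 cells (Homo sapiens) for antiproliferative activity, read by MTT assay, with a stated time of 24 h; a lower number here means a stronger inhibitor, a higher number a weaker inhibitor. Compound 1 `Sc1nnc(-c2ccc3c(c2)OCCO3)n1-c1ccccc1` carries a bare hydrogen on its sulfur and gives 60000 nM. Compound 2 `O=[N+]([O-])c1ccccc1CSc1nnc(-c2ccc3c(c2)OCCO3)n1-c1ccccc1` gives 12000 nM, and compound 3 `O=[N+]([O-])c1cccc(CSc2nnc(-c3ccc4c(c3)OCCO4)n2-c2ccccc2)c1` gives 49300 nM. Compound 3 therefore stands second highest of the three numbers, close to compound 1 and well apart from compound 2. In the measured steps, a 1.2-fold lower number from compound 1 to compound 3 (0.09 log units; within the scatter), a shift that is within the scatter, whereas a 5.0-fold lower number from compound 1 to compound 2 (0.70 log units; beyond the scatter) and a 4.1-fold higher number from compound 2 to compound 3 (0.61 log units; beyond the scatter), both beyond it.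

Compound 4 `Fc1ccccc1CSc1nnc(-c2ccc3c(c2)OCCO3)n1-c1ccccc1` is the next compound to be measured. Compared with compound 3, (2-fluorophenyl in place of 3-nitrophenyl on a saturated chain carbon bound to a sulfur). Among the measured compounds shown here, none of the measured compounds carries a fluorine, so no step speaks directly to this swap. For the measured compounds named here, the steps that bear on it concern where the substituent sits on the benzyl arm: the 2-substituted arm of compound 2 gave the lowest number, and the 3-substituted arm of compound 3 hardly moved the number from compound 1. Because of a 4.1-fold higher number from compound 2 to compound 3 (0.61 log units; beyond the scatter), a move to a 2-substituted arm is expected to lower the number moderately. Compound 4 is accordingly estimated at 20000 nM in this assay, with a likely range from 6000 nM to 60000 nM. That estimate for compound 4 amounts to a 2.5-fold lower number from compound 3 to compound 4 (0.39 log units; beyond the scatter), a modest step expected to be just beyond the scatter.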

Compound 4, half-maximal inhibitory concentration: 810 nM
Beside the measured number, compound 4's estimate is 25-fold (1.39 log units) above it; measured number outside the range, below it.
By their numbers in this assay, from the lowest: compound 4; then compound 2; then compounds 3 and 1 (each within the scatter of the next).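

Changing nitro to fluoro on the 2-substituted benzyl arm gives, in this assay, a 15-fold lower number from compound 2 to compound 4 (1.17 log units; beyond the scatter), so the identity of the group on this arm matters greatly, and not only where it sits. The wider comparisons, a 61-fold lower number from compound 3 to compound 4 (1.78 log units; beyond the scatter) and a 74-fold lower number from compound 1 to compound 4 (1.87 log units; beyond the scatter), make compound 4 the strongest inhibitor of the four, although the first of these steps changes both the group and where it sits and cannot separate the two. Nothing available here explains why this swap lowers the number so sharply.

Still open, as far as these compounds go, is whether the fluorine itself must sit where it does in the 2-fluorobenzyl arm, which a 3-fluorobenzyl arm would test, and whether any substituent is needed at all, which a plain benzyl arm would test. It is also unclear how far the trend extends to other groups on the arm, such as 2-chlorobenzyl or 2-methoxybenzyl, or whether the low number of compound 4 would hold in cells other than those used here.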